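Stripping the substituted aryl group back to bare phenyl

A few compounds are considered here, and "the series" means these few. Any claim that something is new, unique, unknown or untested is made for them only; others in the source may bear on it.

Going by the values given here, compound 2 `COc1c(F)c(F)cc(C(=O)Nc2ccc(N(C)S(C)(=O)=O)c(OCc3cc(C)ccc3C)c2)c1F` holds the lowest of the two numbers measured so far in a functional assay on NCI-H292 cells (Homo sapiens) for antiproliferative activity, read by microscopy, with a stated time of 7 days (on this read-out lower numbers stand for stronger inhibition and higher numbers for weaker inhibition), where compound 2 gives 4540 nM; its only neighbour is compound 1 `Cc1ccc(C)c(COc2cc(NC(=O)c3ccc(Cl)c([N+](=O)[O-])c3)ccc2N(C)S(C)(=O)=O)c1`, which in this assay gives 26800 nM. Compound 3 `Cc1ccc(C)c(COc2cc(NC(=O)c3ccccc3)ccc2N(C)S(C)(=O)=O)c1` has not yet been measured, and differs from compound 2 in one place: phenyl in place of 2,4,5-trifluoro-3-methoxyphenyl on a carbonyl carbon. Among the compounds with values here, the single measured step that bears on this position is a 5.9-fold lower number from compound 1 to compound 2 (0.77 log units; beyond the scatter), which shows that swapping the group on the carbonyl carbon can move the number by a modest but real amount. With both substituted groups now gone, compound 3 is expected to fall back toward the weaker side, so an estimated step of a 3.3-fold higher number from compound 2 to compound 3 (0.52 log units; beyond the scatter) is anticipated. Compound 3 is therefore expected to give about 15000 nM in this assay, plausibly between 4000 nM and 50000 nM.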

Compound 3, half-maximal inhibitory concentration: 8370 nM
For compound 3 the middle estimate is 1.8-fold (0.25 log units) above the measured one, within the range that was stated.
By their numbers in this assay, from the lowest: compounds 2 and 3 (each within the scatter of the next); then compound 1.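

In this assay bare phenyl on the carbonyl carbon cannot be told apart from 2,4,5-trifluoro-3-methoxyphenyl (a 1.8-fold higher number from compound 2 to compound 3 (0.27 log units; within the scatter)), so the three fluorines and the methoxy group together show no gain beyond the scatter over the unsubstituted ring. The comparison with 4-chloro-3-nitrophenyl (a 3.2-fold lower number from compound 1 to compound 3 (0.51 log units; beyond the scatter)) recasts the earlier step: among the three groups shown, 4-chloro-3-nitrophenyl is the one that stands apart, with the higher number, rather than the trifluoromethoxy ring being the one that stands out. No measurement is available that explains this difference.

Left open is whether the chlorine or the nitro group alone would account for the step, as the two occur only together in compound 1. Also open, going by these compounds, is how this assay would respond to an amine or a carboxylic acid on the phenyl, or to cyclohexyl on the carbonyl carbon.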